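The source may report more compounds than this note shows. Statements on the series, on what has been measured and on what is new or still open speak of the compounds shown alone.

Measured so far:
Compound 1 `CNC(=O)c1cnc(N2CCN(C3CCN(Cc4ccc(Cl)cc4)CC3)[C@@H](C)C2)c(Cl)c1` — in a functional assay for antagonist activity at C-X-C chemokine receptor type 3 (Homo sapiens) (on this read-out lower numbers stand for stronger inhibition and higher numbers for weaker inhibition), compound 1 gives 32 nM.
Compound 2 `CNC(=O)c1cnc(N2CCN(C3CCN(Cc4ccc(C)cc4)CC3)[C@@H](C)C2)c(Cl)c1` — in this assay compound 2 gives 87 nM.

Within the data shown here, compound 2 stands at the higher of the two numbers; its only neighbour is compound 1, and the step of a 2.7-fold higher number from compound 1 to compound 2 (0.43 log units; beyond the scatter) lies beyond the scatter, so compound 2 is the weaker of the pair on this read-out. Compound 3 `CNC(=O)c1cnc(N2CCN(C3CCN(Cc4ccc(Cl)cc4Cl)CC3)[C@@H](C)C2)c(Cl)c1` is not yet measured. Against compound 2 the change is 2,4-dichlorophenyl in place of 4-methylphenyl on a saturated chain carbon bound to an amine nitrogen in a ring. Among the measured compounds shown here, the one measured step that bears on this is a 2.7-fold higher number from compound 1 to compound 2 (0.43 log units; beyond the scatter), in which methyl in place of chloro on that ring raised the number modestly. For the measured compounds named here, compound 3 brings the chloro of compound 1 back and carries a second chloro on the same ring; for the second chloro no measured step exists, so its contribution is open. The expectation is therefore a lower number for compound 3 than for compound 2, of about the size of the reverse of the chloro-to-methyl step, with a range widened for the second chloro. Compound 3 is expected at 30 nM, between 10 nM and 90 nM, a step of a 2.9-fold lower number from compound 2 to compound 3 (0.46 log units; beyond the scatter).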

Compound 3, half-maximal inhibitory concentration: 17 nM
For compound 3 the middle estimate is 1.8-fold (0.25 log units) above the measured one; the range from low to high includes it.
By their numbers in this assay, from the lowest: compounds 3 and 1 (each within the scatter of the next); then compound 2.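

In this assay, the full change on the benzyl group, 4-methylbenzyl to 2,4-dichlorobenzyl, gives a 5.1-fold lower number from compound 2 to compound 3 (0.71 log units; beyond the scatter), so this position on a saturated chain carbon bound to an amine nitrogen in a ring accepts a ring with two chloro groups without loss against compound 2. The second chloro read alone gives a 1.9-fold lower number from compound 1 to compound 3 (0.27 log units; within the scatter), so compound 1 and compound 3 are not separated on this read-out, and the second chloro can be said to be accepted but not to bring a gain; what separates compound 2 from the other two is therefore tied in these compounds to the methyl group, not to the added chloro. No measurement on these compounds speaks to why the numbers fall as they do.

On these data alone, whether a methoxy group, a nitrile or a trifluoromethyl group on this ring would hold the number of the chloro compounds remains open. Also open, as far as these compounds go, is whether the second chloro would show a clearer step on the methyl-bearing ring of compound 2, where the starting number is weaker.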